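A few compounds are considered here, and "the series" means these few. Any claim that something is new, unique, unknown or untested is made for them only; others in the source may bear on it.

In a functional assay on HCC 2998 cells (Homo sapiens) for antiproliferative activity (on this read-out lower numbers stand for stronger inhibition of growth and higher numbers for weaker inhibition of growth), compound 2 `Oc1ccc(-c2nc3ccccc3s2)cc1O` gives 6990 nM and compound 3 `COc1ccc(-c2nc3cc(F)ccc3s2)cc1` gives 12400 nM, two values that lie within the usual scatter of each other. Compound 1 `Cc1cc(-c2nc3ccccc3s2)ccc1N` reads > 100000 nM, which is a limit of the assay and not a number. Compound 4 `COc1ccc(-c2nc3cc(F)ccc3s2)cc1F` is compound 3 with fluoro in place of hydrogen on an aromatic carbon, ortho to a methoxy group and meta to a large group: fluoro in place of hydrogen on an aromatic carbon. Within the data shown here, no measured pair of compounds shows what such a change does, so in this assay no clear direction and no step beyond the scatter is expected. The expected step is a 1.2-fold lower number from compound 3 to compound 4 (0.09 log units; within the scatter). For compound 4 the estimated value is 10000 nM, with an expected range of 3500 nM to 30000 nM.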

Compound 4, concentration for 50% growth inhibition: 13700 nM
For compound 4 the middle estimate is 1.4-fold (0.14 log units) below the measured one, and the stated range covers the measured number.
By their numbers in this assay, from the lowest: compounds 2, 3 and 4 (each within the scatter of the next). At a limit, above all of these: compound 1.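

Fluoro in place of hydrogen on an aromatic carbon, ortho to a methoxy group and meta to a large group, gives in this assay a 1.1-fold higher number from compound 3 to compound 4 (0.04 log units; within the scatter). This is the first change in a single place among the compounds shown, and here hydrogen and fluoro give numbers within the scatter of each other. Compound 1 is the only compound shown at a limit, which is not a number: the limit of > 100000 nM in this assay, at which 1 of the 4 values shown sits. From the compounds shown here alone, whether an amine, a carboxylic acid or a longer chain in this place would give a different number stays open. So does whether fluoro would give the same small step elsewhere on this ring.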